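Working notes on a carbamoyl change at an amine nitrogen

The compounds below may be only part of what the source reports. "The series", "measured", "known", "first", "only" and "open" are said of these compounds alone.

Measured so far in a physicochemical assay for inhibition, read by spectrophotometry, tested at 100 uM; a lower number here means less inhibition, a higher number more inhibition at the concentration tested (going by the name of the read-out):
Compound 1, `COc1cc(NC(C)CCCNC(=O)NNC(=O)NCCCCCO)c2ncccc2c1`, gives 54%.
Compound 2, `COc1cc(NC(C)CCCNC(=O)NNC(=O)Nc2ccc(Cl)c(C(F)(F)F)c2)c2ncccc2c1`, gives 63%.
Compound 3, `COc1cc(NC(C)CCCNC(=O)NN)c2ncccc2c1`, gives 70%.

Compound 3 holds the highest of the three numbers; the gap to compound 2 lies within the scatter, the gap to compound 1 beyond it. Compound 4, `COc1cc(NC(C)CCCNC(=O)NNC(=O)NCCO)c2ncccc2c1`, differs from compound 3 as follows: (2-hydroxyethyl)carbamoyl in place of hydrogen on an amine nitrogen. The step that bears on this is the reverse kind of change, a number 16 percentage points higher from compound 1 to compound 3 (beyond the scatter), where removing a carbamoyl group raised inhibition. The step of a number 9 percentage points higher from compound 1 to compound 2 (within the scatter) shows that the group carried on the carbamoyl matters little. A modest fall is therefore expected, a number 13 percentage points lower from compound 3 to compound 4 (beyond the scatter). Compound 4 is estimated at 57%, within 44% to 70%.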

Compound 4, a percentage reported as inhibition, at one concentration (the size of the read-out at that concentration, not a potency): 27%
For compound 4 the middle estimate is 30 percentage points above the measured one; the measured number lies below the stated range.
By their numbers in this assay, from the lowest: compound 4; then compounds 1, 2 and 3 (each within the scatter of the next, the first and the last beyond it).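

In this assay, (2-hydroxyethyl)carbamoyl in place of hydrogen on the amine nitrogen gives a far from neutral change: a number 43 percentage points lower from compound 3 to compound 4 (beyond the scatter). The group carried on the carbamoyl therefore matters, with 2-hydroxyethyl in place of 4-chloro-3-(trifluoromethyl)phenyl giving a number 36 percentage points lower from compound 2 to compound 4 (beyond the scatter), and the shorter hydroxy chain giving a number 27 percentage points lower from compound 1 to compound 4 (beyond the scatter). Nothing available explains these falls.

With only two hydroxy chains shown, the trend with chain length remains open. Also open, on these data alone, is how a 3-hydroxypropyl chain, a 2-aminoethyl group or a carboxymethyl group would read on the carbamoyl.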